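Amino for Hydroxy on Two Related Nucleoside Cores

The source may hold more compounds than are shown below. What is called first, only, known or untested is meant among the compounds shown, and "the series" means these compounds.

Measured so far:
compound 1, `N#C[C@]1(O)[C@H](O)[C@@H](CO)O[C@@H](n2ccc(O)nc2=O)[C@@H]1O`, > 500000 nM
compound 2, `N#C[C@]1(O)[C@H](O)[C@@H](CO)O[C@@H](n2ccc(N)nc2=O)[C@@H]1O`, 377000 nM
compound 3, `N#C[C@H]1[C@@H](O)[C@H](n2ccc(O)nc2=O)O[C@H](CO)[C@H]1O`, 811000 nM

Of the compounds shown here, three have been tested in a functional assay on HeLa cells (Homo sapiens); on this read-out lower numbers stand for stronger inhibition and higher numbers for weaker inhibition. Compound 1 gives > 500000 nM, and that value is a limit of the assay rather than a number, a point noted as the limit of > 500000 nM in this assay, at which 1 of the 3 values shown sits. Compound 2 differs from compound 1 in one place, (amino in place of hydroxy on an aromatic carbon). In this assay compound 2 gives 377000 nM. The step is an at least 1.3-fold lower number from compound 1 to compound 2 (0.12 log units; that floor lies within the scatter). Compound 3 sits on a different core, and the difference between the two cores is not broken down here. In this assay compound 3 gives 811000 nM, a higher number than that of compound 2.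

Compound 4, `N#C[C@H]1[C@@H](O)[C@H](n2ccc(N)nc2=O)O[C@H](CO)[C@H]1O`, has not been measured. It stands to compound 3 as compound 2 stands to compound 1: the change is amino in place of hydroxy on an aromatic carbon, and since the place of the change is described in the same words for both pairs, it is the same change, made twice among these four compounds. Going by the values given here, the only guide is the step from compound 1 to compound 2, which is a floor within the usual scatter, so a modest lowering of the number is expected at most. The step to compound 4 is estimated as a 1.6-fold lower number from compound 3 to compound 4 (0.21 log units; within the scatter), resting on the step of an at least 1.3-fold lower number from compound 1 to compound 2 (0.12 log units; that floor lies within the scatter). Compound 4 is expected to give about 500000 nM, likely between 200000 nM and 1200000 nM.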

Compound 4, half-maximal inhibitory concentration: > 750000 nM
Compound 4: only a limit was reported (the forecaster's own chance of this, stated with the estimate: 15%); middle value at least 1.5-fold (0.17 log units) away from the limit.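

In this assay compound 4 gives > 750000 nM, which is a limit of the assay and not a number. The step from compound 3 to compound 4 therefore cannot be read: the limit of > 750000 nM in this assay, at which 1 of the 4 values shown sits.

The compounds shown leave open whether amino in place of hydroxy on an aromatic carbon changes the number at all on either core, since compound 1 also carries a limit: the limit of > 500000 nM in this assay, at which 1 of the 4 values shown sits.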